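A few compounds are considered here, and "the series" means these few. Any claim that something is new, unique, unknown or untested is made for them only; others in the source may bear on it.

Compounds measured in a functional assay on CHO cells for agonist activity at Free fatty acid receptor 1 (Homo sapiens), read by FLIPR and calcium flux; on this read-out lower numbers stand for an effect already at smaller amounts and higher numbers for an effect only at larger amounts of compound:

Compound 1, `COc1cc(C)c(-c2cccc(COc3ccc(S(=O)(=O)CC(=O)O)cc3)c2)c(C)c1`, gives 57.5 nM.
Compound 2, `COc1cc(C)c(-c2cccc(COc3ccc(S(=O)(=O)C(C)C(=O)O)cc3)c2)c(C)c1`, gives only a limit of the assay, > 1000 nM.
Compound 3, `COc1cc(C)c(-c2cccc(COc3ccc(S(=O)(=O)C(C)(C)C(=O)O)cc3)c2)c(C)c1`, likewise gives only a limit, > 1000 nM.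

Compound 3 therefore does not stand at a number at all: its value is a limit, and it shares that with one other of the three, as the limit of > 1000 nM in this assay, at which 2 of the 3 values shown sit, records. The step from compound 1, where the chain next to the sulfonyl sulfur carries hydrogen only, is an at least 17-fold higher number from compound 1 to compound 3 (1.24 log units; beyond the scatter); the related single methylation is an at least 17-fold higher number from compound 1 to compound 2 (1.24 log units; beyond the scatter). The further methylation is a step that the two limits leave unreadable from compound 2 to compound 3, so nothing can be read about whether more substitution at that carbon matters once the limit is reached.

Compound 4 is `COc1cc(C)c(-c2cccc(COc3ccc(S(=O)(=O)C4(C(=O)O)CC4)cc3)c2)c(C)c1`. It differs from compound 3 by 1-carboxycyclopropyl in place of 1-carboxy-1-methylethyl on a sulfonyl sulfur; the carbon bound to the sulfonyl sulfur remains fully substituted, and only the shape of its two carbon substituents changes. Since both substituted analogues sit at the limit, the expectation for compound 4 in this assay is a value at or beyond the same limit, with the step that the limit leaves unreadable from compound 3 to compound 4 expected. The estimate for compound 4 is 3000 nM, within 800 nM to 15000 nM.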

Compound 4, half-maximal effective concentration in the Free fatty acid receptor 1 assay: > 1000 nM
Compound 4: only a limit was reported; the forecaster's own chance of this, stated with the estimate: 70%; the middle value is on the limit's open side.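

In the Free fatty acid receptor 1 assay compound 4 gives > 1000 nM, which is a limit of the assay and not a number. Tying the two carbon substituents into a three-membered ring, as in 1-carboxycyclopropyl, therefore does not restore a measurable value in the Free fatty acid receptor 1 assay, and the change from carboxymethyl on the sulfonyl sulfur is an at least 17-fold higher number from compound 1 to compound 4 (1.24 log units; beyond the scatter). The steps from compound 2 and from compound 3 to compound 4 cannot be read, and among the compounds shown only compound 1, with hydrogen alone on the carbon bound to the sulfonyl sulfur, gives a number, so the ring form joins methyl and gem-dimethyl substitution on the far side of the assay's limit, as the record now stands: the limit of > 1000 nM in the Free fatty acid receptor 1 assay, at which 3 of the 4 values shown sit.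

How far compound 2, compound 3 and compound 4 lie beyond that limit stays unknown, so no order among these three can be given. On these data alone, it also remains open whether a single fluorine on that carbon in place of hydrogen, or a longer chain carrying the carboxylic acid further from the sulfonyl sulfur, would keep a value near that of compound 1.

In a physicochemical assay for lipophilicity, using the shake flask method, in phosphate buffer, measured as octanol-water partition, with a stated time of 24 h, at pH 7.4, tested at 100 uM (a higher number here means a more lipophilic compound, a lower number a more polar compound), compound 3 is recorded as "not determined" (no result reported). In the physicochemical assay compound 4 is likewise recorded as "not determined" (no result reported), so no result is reported for either compound there.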